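The source may hold more compounds than are shown below. What is called first, only, known or untested is meant among the compounds shown, and "the series" means these compounds.

Of the compounds shown here, three have so far been measured in an assay for inhibition of alcohol dehydrogenase (Equus caballus); a higher number here means a weaker inhibitor, a lower number a stronger inhibitor. Compound 1 `COCC(N)=O` gives 600000 nM, and compound 3 `NC(=O)CSCC(N)=O` gives 36000000 nM. Compound 2 `NC(=O)CCCCO` gives 4400000 nM, the second highest of the three numbers, beyond the scatter from both of its neighbours: compound 1 lies at a lower number and compound 3 at a higher one.

The step of interest leads from compound 2 to compound 4 `NC(=O)CCCCCO`, the change being hydroxymethyl in place of hydroxy on a saturated chain carbon, four bonds along the chain from a carbonyl carbon. For the measured compounds named here, no measured pair shows a comparable step. A small move toward a lower number is expected, estimated at about a 1.8-fold lower number from compound 2 to compound 4 (0.25 log units; within the scatter). Compound 4 is therefore estimated at 2500000 nM, within a range from 700000 nM to 9000000 nM.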

Compound 4, inhibition constant: 1500000 nM
Compound 4: middle estimate off by 1.7-fold (0.22 log units), on the high side, within the range that was stated.
By their numbers in this assay, from the lowest: compound 1; then compound 4; then compound 2; then compound 3.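

In this assay, for the compounds shown here, hydroxymethyl in place of hydroxy on a saturated chain carbon, four bonds along the chain from a carbonyl carbon, gives a 2.9-fold lower number from compound 2 to compound 4 (0.47 log units; beyond the scatter), the first step that can be read at this position. The position therefore responds to this change, and the longer group goes with the stronger inhibitor of the pair. Nothing measured here explains the step. The compounds leave open whether 2-hydroxyethyl at this place would extend the move, and how an amine or a carboxylic acid in place of the hydroxy would compare.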